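Swapping halogens on the core: expected cytotoxicity of compound 3

A few compounds are considered here, and "the series" means these few. Any claim that something is new, unique, unknown or untested is made for them only; others in the source may bear on it.

Compound 1 `O=C1O/C(=C\Cn2cnc3c(F)nc(F)c(Cl)c32)C(OCc2ccccc2)=C1OCc1ccccc1`: > 100000 nM
Compound 2 `COc1nc(OC)c2c(ccn2C/C=C2\OC(=O)C(OCc3ccccc3)=C2OCc2ccccc2)n1`: >= 20000 nM

The two measured compounds were examined in an ADME assay on HEL cells (Homo sapiens) for cytotoxicity, read by microscopy, with a stated time of 3 days; a higher number here means that more compound is tolerated, a lower number that less compound is tolerated. Compound 1 gives > 100000 nM, which is a limit of the assay rather than a number; see (the limit of > 100000 nM in this assay, at which 1 of the 2 values shown sits). Compound 2 gives >= 20000 nM, again a limit and not a number; see (the limit of >= 20000 nM in this assay, at which 1 of the 2 values shown sits). Among the compounds with values here, no step between the two measured compounds is available, since they differ in more than one place, so the two values show only that neither reached a measurable cytotoxic concentration. Compound 1 therefore stands at the upper limit of what this assay reports.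

Compound 3 `O=C1O/C(=C\Cn2cnc3c(Cl)c(F)nc(F)c32)C(OCc2ccccc2)=C1OCc1ccccc1` has not been measured in this assay. It differs from compound 1 by a group of 12 heavy atoms (6 carbon, 3 nitrogen, 2 fluorine, 1 chlorine; one five-membered aromatic ring with 2 hetero atoms, one six-membered aromatic ring with 1 hetero atom) in place of a group of 12 heavy atoms (6 carbon, 3 nitrogen, 2 fluorine, 1 chlorine; one five-membered aromatic ring with 2 hetero atoms, one six-membered aromatic ring with 1 hetero atom), on a saturated chain carbon bound to a double-bonded chain carbon; the two have the same atoms, joined differently. Within the data shown here, with no step recorded between measured compounds, the expected step from compound 1 to compound 3 is a number no higher from compound 1 to compound 3 (the limit leaves the size open), that is, none beyond the scatter. Compound 3 is expected to give 100000 nM, in the range 30000 nM to 300000 nM, most likely reported again as a limit.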

Compound 3, minimum cytotoxic concentration: >= 100000 nM
Compound 3: a limit, no number; the forecaster's own chance of this, stated with the estimate: 85%; the middle value lies on the limit itself.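

In this assay compound 3 gives >= 100000 nM, which is a limit of the assay and not a number. Within the data shown here, compound 1 likewise stands at a limit, > 100000 nM, so no step from compound 1 to compound 3 can be read. The compounds shown leave open whether rearranging the halogens on the core changes cytotoxicity at all.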